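This account rests on a few compounds, and the source may have more. Where it says the series, first, only, none or still open, it means among the compounds named here.

Compound 1 `CN(C)C(=O)c1cnc(C(=O)CCc2ccc(COc3ccccc3)cc2)o1`: 6.7 nM
Compound 2 `O=C(O)c1cccc(-c2cnc(C(=O)CCc3ccc(-c4ccc(CN5CCCCC5)cc4)cc3)o2)n1`: 44 nM

Both compounds were tested in an assay for inhibition of Fatty-acid amide hydrolase 1 (Rattus norvegicus); a higher number here means a weaker inhibitor, a lower number a stronger inhibitor. Compound 1 gives 6.7 nM, the lower of the two numbers, while compound 2 gives 44 nM, a higher number beyond the usual scatter. Compound 3 `COC(=O)c1ccc(-c2cnc(C(=O)CCc3ccc(COc4ccccc4)cc3)o2)nc1` awaits measurement in this assay. It differs from compound 1 in one place: 5-(methoxycarbonyl)pyridin-2-yl in place of dimethylcarbamoyl on an aromatic carbon. For the measured compounds named here, no measured pair shows this exact change. A modest step toward a weaker inhibitor is expected, a 2.2-fold higher number from compound 1 to compound 3 (0.35 log units; beyond the scatter), because compound 2 with its large aromatic group gives 44 nM. Compound 3 is estimated at 15 nM, within 4 nM to 60 nM.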

Compound 3, inhibition constant: 3.5 nM
Compound 3: middle estimate off by 4.3-fold (0.63 log units), on the high side; the whole stated range lies above it.
By their numbers in this assay, from the lowest: compounds 3 and 1 (each within the scatter of the next); then compound 2.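

Measured in this assay the swap of dimethylcarbamoyl for 5-(methoxycarbonyl)pyridin-2-yl gives a 1.9-fold lower number from compound 1 to compound 3 (0.28 log units; within the scatter) and so leaves the number within the scatter. This position, next to the ring oxygen, therefore accepts a much larger group carrying a six-membered aromatic ring without a change that can be read. Nothing measured here explains why these two groups give such similar numbers.

Still open, as far as these compounds go, is whether the methoxycarbonyl itself matters to the number. Compound 3 with a carboxylic acid or an amide in its place would address this.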